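Swapping a Pyridine for a Cyclohexene on the Core

The source may report more compounds than this note shows. Statements on the series, on what has been measured and on what is new or still open speak of the compounds shown alone.

Measured so far:
compound 1 `CCN(c1ccc(C#N)c(Cl)c1)c1cc(-c2ccncc2)ccc1C`: 2900 nM
compound 2 `CCN(c1cccc(-c2ccccc2)c1)c1ccc(C#N)c(Cl)c1`: "not determined" (no result reported)
compound 3 `CCN(c1cccc(-n2ccnc2)c1)c1ccc(C#N)c(C(F)(F)F)c1`: a limit, > 30000 nM

Among the compounds with values here, in a functional assay on VCaP cells (Homo sapiens) for antiproliferative activity, read by CCK-8 assay, with a stated time of 6 days (a lower number here means a stronger inhibitor, a higher number a weaker inhibitor), compound 1 gives 2900 nM, the only plain number among the three compounds. For compound 2 the outcome is "not determined" (no result reported). Compound 3 sits at the limit of > 30000 nM in this assay, at which 1 of the 3 values shown sits, which is a limit of the measurement and not a number. Compound 4 `CCN(c1ccc(C#N)c(Cl)c1)c1cc(C2=CCCCC2)ccc1C` differs from compound 1 in one place: cyclohex-1-en-1-yl in place of pyridin-4-yl on an aromatic carbon. Within the data shown here, no measured pair shows what this kind of change does, so the step is estimated rather than known; a modest move toward weaker inhibition is expected, a 2.1-fold higher number from compound 1 to compound 4 (0.32 log units; beyond the scatter). Compound 4 is accordingly expected to give about 6000 nM, with a likely range from 1500 nM to 25000 nM.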

Compound 4, half-maximal inhibitory concentration: 20000 nM
Compound 4: the middle estimate sits 3.3-fold (0.52 log units) below what was measured, within the range that was stated.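

At the aromatic carbon para to the methyl group, this assay shows a first measured step: replacing pyridin-4-yl with cyclohex-1-en-1-yl gives a 6.9-fold higher number from compound 1 to compound 4 (0.84 log units; beyond the scatter) and so weakens inhibition. An all-carbon, non-aromatic ring of the same size therefore does not stand in for the pyridine here without loss. Nothing shown explains this step.

Within the data shown here, the single change removes both the ring nitrogen and the aromatic ring, so their shares remain unseparated. Going by these compounds, how an amine such as piperidin-4-yl or a carboxylic acid would behave at this position remains open.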